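The source may hold more compounds than are shown below. What is called first, only, known or untested is meant among the compounds shown, and "the series" means these compounds.

Compound 1 `S=C(N/N=C\c1ccccc1)N(Cc1ccccc1)Cc1ccccc1`, compound 2 `C=CCN(CC=C)C(=S)N/N=C(/C)c1ccccc1` and compound 3 `Oc1ccccc1/C=N\NC(=S)N(Cc1ccccc1)Cc1ccccc1` share a thiourea-linked hydrazone arrangement and were all tested in an ADME assay on Vero cells (Chlorocebus sabaeus) for cytotoxicity, read by MTT assay, with a stated time of 72 h; on this read-out lower numbers stand for higher toxicity in this test and higher numbers for lower toxicity in this test. In that test compound 1 gives 174000 nM, compound 2 gives 229000 nM, and compound 3 gives 166000 nM. The difference between the cores of compound 1 and compound 2 is not broken down here. Compound 3 differs from compound 1 by hydroxy in place of hydrogen on an aromatic carbon, and in this assay this change produced a 1.0-fold lower number from compound 1 to compound 3 (0.02 log units; within the scatter), so the two values are indistinguishable. The value of compound 2 lies within the scatter of both compound 1 and compound 3, so no ranking among the three can be drawn from these numbers.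

Compound 4 `C=CCN(CC=C)C(=S)N/N=C(/C)c1ccccc1O` has not yet been measured. It differs from compound 2 by hydroxy in place of hydrogen on an aromatic carbon, the same change, at a place described in the same words as before, on an aromatic carbon of a six-membered aromatic ring of carbon only, ortho to a large group, that separates compound 1 from compound 3.

For compound 4 in this assay the expected step is a 1.0-fold lower number from compound 2 to compound 4 (0.02 log units; within the scatter), because a 1.0-fold lower number from compound 1 to compound 3 (0.02 log units; within the scatter) shows that this change left the read-out essentially where it was. Compound 4 is therefore expected to give about 220000 nM, with a likely range from 110000 nM to 440000 nM.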

Compound 4, half-maximal cytotoxic concentration: 216000 nM
Compound 4: middle estimate off by 1.0-fold (0.01 log units), on the high side, and the stated range covers the measured number.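

On the core of compound 2, hydroxy in place of hydrogen on an aromatic carbon gave a 1.1-fold lower number from compound 2 to compound 4 (0.03 log units; within the scatter) in this assay, so here too the change left the read-out where it was. Set beside the same change on the core of compound 1, the two steps agree: the same change on two cores in this assay, a 1.0-fold lower number (0.02 log units; within the scatter) from compound 1 to compound 3 and a 1.1-fold lower number (0.03 log units; within the scatter) from compound 2 to compound 4, 1.0-fold (0.00 log units) apart, within the scatter of two such steps

This shows that on these two cores the result carries over, and a step read on one core would have served as a fair guide to the other; what carries over, however, is the absence of a visible effect, not a shift in cytotoxicity that repeats in size, and two cores in a single cell test cannot show that the same would hold on every core in the series or in any other test.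

The compounds shown leave open whether a different group on that same aromatic carbon, ortho to a large group, such as an amine, a methoxy group or a carboxylic acid, would move the number beyond the scatter. They also leave open whether hydroxy would still change nothing on a core carrying a longer chain on the thiourea nitrogen.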